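Amine ring size on the propenamide side chain

The compounds below may be only part of what the source reports. "The series", "measured", "known", "first", "only" and "open" are said of these compounds alone.

The series shares one core and varies two places. Compound 1 `COc1cc2ncnc(N3CCc4ccccc43)c2cc1NC(=O)/C=C/CN1CCCC1` gives 1510 nM in a functional assay on MCF7 cells (Homo sapiens) for antiproliferative activity, read by MTT assay, with a stated time of 72 h; a higher number here means a weaker inhibitor, a lower number a stronger inhibitor. Compound 2 `COc1cc2ncnc(N3CCc4ccccc43)c2cc1NC(=O)/C=C/CN1CCCCC1` gives 1680 nM in this assay. Compound 3 `O=C(/C=C/CN1CCCC1)Nc1cc2c(N3CCc4ccccc43)ncnc2cc1O[C@@H]1CCOC1` gives 2310 nM in this assay. Compound 4 `O=C(/C=C/CN1CCCCC1)Nc1cc2c(N3CCc4ccccc43)ncnc2cc1O[C@@H]1CCOC1` has not yet been measured in this assay.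

Two changes are measured. The first, (piperidin-1-yl in place of pyrrolidin-1-yl on a saturated chain carbon bound to a double-bonded chain carbon), made the step of a 1.1-fold higher number from compound 1 to compound 2 (0.05 log units; within the scatter). The second, (oxolan-3-yl in place of methyl on an oxygen on an aromatic ring), made the step of a 1.5-fold higher number from compound 1 to compound 3 (0.18 log units; within the scatter). Compound 2 and compound 3 are not connected by a single change. Compound 2 gives 1680 nM and compound 3 gives 2310 nM, and these two values lie within the scatter of each other. No value among the three stands apart from the others beyond the scatter.

Compound 4 carries the change (piperidin-1-yl in place of pyrrolidin-1-yl on a saturated chain carbon bound to a double-bonded chain carbon). The place is the same word for word as in the step from compound 1 to compound 2, so this is the same change applied to a different core; the two cores differ by oxolan-3-yl in place of methyl on an oxygen on an aromatic ring. The step from compound 3 to compound 4 in this assay is expected to be a 1.1-fold higher number from compound 3 to compound 4 (0.03 log units; within the scatter), set beside the earlier step of a 1.1-fold higher number from compound 1 to compound 2 (0.05 log units; within the scatter). This rests on compound 1 and compound 2, whose step a 1.1-fold higher number from compound 1 to compound 2 (0.05 log units; within the scatter) stayed within the scatter, and on compound 3 at 2310 nM as the starting point. Compound 4 is expected at 2500 nM in this assay. The expected range for compound 4 runs from 1300 nM to 4800 nM.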

Compound 4, half-maximal inhibitory concentration: 1890 nM
The estimate for compound 4 lay 1.3-fold (0.12 log units) above the measured number; low and high end bracket the measured number.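

In this assay, piperidin-1-yl in place of pyrrolidin-1-yl reads as a 1.2-fold lower number from compound 3 to compound 4 (0.09 log units; within the scatter) on the core carrying oxolan-3-yl, and this does not differ from the step on the core of compound 1: the same change on two cores in this assay, a 1.1-fold higher number (0.05 log units; within the scatter) from compound 1 to compound 2 and a 1.2-fold lower number (0.09 log units; within the scatter) from compound 3 to compound 4, 1.4-fold (0.13 log units) apart, within the scatter of two such steps. Oxolan-3-yl in place of methyl, read on the core carrying piperidin-1-yl, comes out as a 1.1-fold higher number from compound 2 to compound 4 (0.05 log units; within the scatter), and it too matches its earlier step: the same change on two cores in this assay, a 1.5-fold higher number (0.18 log units; within the scatter) from compound 1 to compound 3 and a 1.1-fold higher number (0.05 log units; within the scatter) from compound 2 to compound 4, 1.4-fold (0.13 log units) apart, within the scatter of two such steps. Across these four compounds, both changes therefore carry from one core to the other with no detectable shift, but every step lies within the scatter, so this shows only that neither change moves the number measurably on either core; it does not show how a change with a step beyond the scatter would carry over, nor does it establish that the two places act independently in general.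

From the compounds shown here alone, whether the same picture holds for morpholin-4-yl, for an open-chain amine such as dimethylamino, or for a longer chain carrying the amine remains open. Also open, going by these compounds, is whether a larger ether on the oxygen, such as tetrahydropyran-4-yl, would leave the number as undisturbed as oxolan-3-yl does.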